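A few compounds are considered here, and "the series" means these few. Any claim that something is new, unique, unknown or untested is made for them only; others in the source may bear on it.

Measured so far in a functional assay on MCF7 cells (Homo sapiens) for inhibition, read by sulforhodamine B assay, with a stated time of 48 h; a lower number here means a stronger inhibitor of growth, a higher number a weaker inhibitor of growth:
- compound 1 `C=C(C)[C@@H]1CC=C(Cn2cc(COc3ccc(C4NC(=O)NC(C)=C4C(=O)OCC)cc3)nn2)CC1`: 43100 nM
- compound 2 `C=C(C)[C@@H]1CC=C(Cn2cc(COc3ccc(C4NC(=O)NC(C)=C4C(=O)OCC)cc3OC)nn2)CC1`: 82500 nM
- compound 3 `C=C(C)[C@@H]1CC=C(Cn2cc(COc3cccc(C4NC(=O)NC(C)=C4C(C)=O)c3)nn2)CC1`: 43000 nM

From compound 1 to compound 2 the change is methoxy in place of hydrogen on an aromatic carbon and the step is a 1.9-fold higher number from compound 1 to compound 2 (0.28 log units; within the scatter). Compound 3 carries a different core; the difference between the two cores is not broken down here, and the values of compound 1 and compound 3 lie within the scatter of each other.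

Compound 4 `C=C(C)[C@@H]1CC=C(Cn2cc(COc3cc(C4NC(=O)NC(C)=C4C(C)=O)ccc3OC)nn2)CC1` is not yet measured in this assay. It differs from compound 3 by methoxy in place of hydrogen on an aromatic carbon, the same kind of change as from compound 1 to compound 2, though here the entering group sits para to a large group rather than meta to one. The step from compound 3 to compound 4 is expected to be a 1.6-fold higher number from compound 3 to compound 4 (0.21 log units; within the scatter), resting on the earlier step of a 1.9-fold higher number from compound 1 to compound 2 (0.28 log units; within the scatter). Compound 4 is therefore estimated at 70000 nM, between 30000 nM and 160000 nM.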

Compound 4, concentration for total growth inhibition: > 100000 nM
Compound 4 ended at the assay's limit; the forecaster's own chance of this, stated with the estimate: 20%; middle value at least 1.4-fold (0.15 log units) from the limit.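

In this assay compound 4 gives > 100000 nM, which is a limit of the assay and not a number. Going by these compounds, on the core of compound 3, methoxy in place of hydrogen on an aromatic carbon gives an at least 2.3-fold higher number from compound 3 to compound 4 (0.36 log units; beyond the scatter), so growth inhibition is weaker on this core, though the full size of the step stays unknown. This does not show whether the change carries over with the same size from one core to the other: the same change on two cores in this assay, a 1.9-fold higher number (0.28 log units; within the scatter) from compound 1 to compound 2 and an at least 2.3-fold higher number (0.36 log units; beyond the scatter) from compound 3 to compound 4; the limit leaves it open whether they differ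

The compounds shown leave open whether a hydroxyl, a fluorine or an amine in place of methoxy would give a number that can be read within the assay's range. They also leave open how a longer ether chain at this carbon would compare on either core.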